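A few compounds are considered here, and "the series" means these few. Any claim that something is new, unique, unknown or untested is made for them only; others in the source may bear on it.

Compound 1, with the structure `COc1cc(OC)c(/C=C/S(=O)(=O)Cc2ccc(OC)cc2[N+](=O)[O-])c(OC)c1`, carries a nitro group on an aromatic carbon. In a functional assay on K562 cells (Homo sapiens) for cytotoxicity, read by trypan blue exclusion, with a stated time of 96 h (on this read-out higher numbers stand for weaker inhibition and lower numbers for stronger inhibition), compound 1 gives 20000 nM. Compound 2, with the structure `COc1ccc(CS(=O)(=O)/C=C/c2c(OC)cc(OC)cc2OC)c(N)c1`, differs from compound 1 in one place: amino in place of nitro on an aromatic carbon. In this assay compound 2 gives 25 nM, so the step of an 800-fold lower number from compound 1 to compound 2 (2.90 log units; beyond the scatter) is a large one.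

Compound 3, with the structure `COc1cc(OC)c(/C=C/[S+]([O-])Cc2ccc(OC)c([N+](=O)[O-])c2)c(OC)c1`, is built on a different core from compound 1; the difference between the two cores is not broken down here. In this assay compound 3 gives 15000 nM. Measured against compound 1, compound 3 stands within the usual scatter, so the two numbers cannot be told apart.

Compound 4, with the structure `COc1cc(OC)c(/C=C/[S+]([O-])Cc2ccc(OC)c(N)c2)c(OC)c1`, has not yet been measured. It differs from compound 3 by a single change: amino in place of nitro on an aromatic carbon. Among the measured compounds shown here, this is the same kind of change as the one from compound 1 to compound 2, but not the same: in compound 4 the new group sits ortho to a methoxy group and meta to a large group, whereas in compound 2 it sits ortho to a large group and meta to a methoxy group.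

For the measured compounds named here, compound 4 is therefore expected to show a step of a 380-fold lower number from compound 3 to compound 4 (2.57 log units; beyond the scatter) in this assay, a step set beside the one measured step because an 800-fold lower number from compound 1 to compound 2 (2.90 log units; beyond the scatter) is the only measured example of this kind of change here. Compound 4 is estimated to give 40 nM in this assay, with a likely range from 8 nM to 300 nM.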

Compound 4, half-maximal inhibitory concentration: 20 nM
Beside the measured number, compound 4's estimate is 2.0-fold (0.30 log units) above it; the measured number falls inside the stated range.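

Putting amino in place of nitro on the core of compound 3 gives a 750-fold lower number from compound 3 to compound 4 (2.88 log units; beyond the scatter) in this assay, so compound 4 joins compound 2 on the low side of the numbers shown. Set beside the earlier step, the change carries over from one core to the other at practically the same size: the same change on two cores in this assay, an 800-fold lower number (2.90 log units; beyond the scatter) from compound 1 to compound 2 and a 750-fold lower number (2.88 log units; beyond the scatter) from compound 3 to compound 4, 1.1-fold (0.03 log units) apart, within the scatter of two such steps. This shows that, for these two pairs, the size of the step did not depend on the core, even though the new group sits ortho to a methoxy group and meta to a large group in compound 4 and the other way round in compound 2; it does not show why the step is so large, and two pairs are too few to make a rule for any further core.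

The compounds shown leave open whether a hydroxyl group, an acetamide or a dimethylamino group in place of the nitro group would give a step of this size, or whether the amino group alone does so. They also leave open whether a ring with neither nitro nor amino, carrying only a hydrogen on that carbon, would stand nearer compound 3 or compound 4.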